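Pyrimidine Ring in Place of tert-Butyl on the Piperazine

This account rests on a few compounds, and the source may have more. Where it says the series, first, only, none or still open, it means among the compounds named here.

Among the compounds with values here, compound 1 `Cc1cccc2sc(NC(=O)CCN3CCN(C(C)(C)C)CC3)nc12` is one of two compounds measured in an assay on membranes from liver for displacement of a labelled ligand from Sigma intracellular receptor 2 (Rattus norvegicus), read by scintillation counting, with a stated time of 120 min (on this read-out lower numbers stand for stronger inhibition and higher numbers for weaker inhibition), where compound 1 gives 200 nM. Within the data shown here, the only other measured compound, compound 2 `CCCCN1CCN(CCC(=O)Nc2nc3c(C)cccc3s2)CC1`, gives 1200 nM in this assay, and the single measured step is a 6.0-fold higher number from compound 1 to compound 2 (0.78 log units; beyond the scatter), so compound 1 stands with the lower of the two numbers. Compound 3 `Cc1cccc2sc(NC(=O)CCN3CCN(c4ncccn4)CC3)nc12` differs from compound 1 by pyrimidin-2-yl in place of tert-butyl on an amine nitrogen in a ring. Among the measured compounds shown here, the one measured step swaps one chain for another on that same ring nitrogen and shows that changing the group there can move the number well beyond the scatter, but no measured step places an aromatic ring on that nitrogen, so the direction of this change cannot be read from the data. A modest weakening is nonetheless expected, a 3.0-fold higher number from compound 1 to compound 3 (0.48 log units; beyond the scatter). Compound 3 is therefore estimated to give 600 nM in this assay, with a range from 150 nM to 2500 nM.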

Compound 3, inhibition constant: > 1000 nM
Compound 3: only a limit was reported; the forecaster's own chance of this, stated with the estimate: 5%; middle value at least 1.6-fold (0.22 log units) from the limit.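

Pyrimidin-2-yl in place of tert-butyl on this amine nitrogen in a ring gives an at least 5.0-fold higher number from compound 1 to compound 3 (0.69 log units; beyond the scatter), the only step shown that places an aromatic ring there, and it joins butyl in compound 2 in moving the number up from that of compound 1. In this assay, compound 3 gives > 1000 nM, which is a limit of the assay and not a number: the limit of > 1000 nM in this assay, at which 1 of the 3 values shown sits. The step from compound 2 to compound 3 cannot be read, so butyl and pyrimidin-2-yl cannot be ranked against each other.

From the compounds shown here alone, how far the true number of compound 3 lies past its limit stays open. Also open, going by these compounds, is whether a phenyl ring or a cyclohexyl ring on the same nitrogen would give a number closer to that of compound 1 or to that of compound 3.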